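Cytotoxicity of a triazole ester series: methoxyphenyl analogue

The source may hold more compounds than are shown below. What is called first, only, known or untested is meant among the compounds shown, and "the series" means these compounds.

The series shares a terpenoid ester core joined to a triazole whose aromatic nitrogen carries an aryl group. Compound 1 `C/C(=C\CC/C(C)=C/CC[C@@H]1[C@@]2(C)CCC(=O)C(C)(C)[C@H]2CC[C@@]1(C)O)CC/C=C(\C)C(=O)OCc1cn(-c2cccc(O)c2)nn1` carries a 3-hydroxyphenyl there, and in an ADME assay on L132 cells (Homo sapiens) for cytotoxicity, read by MTT assay, with a stated time of 48 h (a higher number here means a weaker inhibitor, a lower number a stronger inhibitor), compound 1 gives 146000 nM. Compound 2 `C/C(=C\CC/C(C)=C/CC[C@@H]1[C@@]2(C)CCC(=O)C(C)(C)[C@H]2CC[C@@]1(C)O)CC/C=C(\C)C(=O)OCc1cn(C[C@@H]2O[C@H](n3ccc(=O)[nH]c3=O)[C@H]3OC(C)(C)O[C@H]32)nn1` carries a protected nucleoside instead. For compound 2 the result in this assay is only a limit of the assay, > 150000 nM. Compound 3 `C/C(=C\CC/C(C)=C/CC[C@@H]1[C@@]2(C)CCC(=O)C(C)(C)[C@H]2CC[C@@]1(C)O)CC/C=C(\C)C(=O)OCc1cn(-c2ccc(F)cc2)nn1` carries a 4-fluorophenyl. For compound 3 the result in this assay is likewise a limit, > 150000 nM, so compound 3 stands at the ceiling of what was measured rather than at a number, a position shared by most of the series (the limit of > 150000 nM in this assay, at which 2 of the 3 values shown sit). Going by the values given here, the one measured step that touches compound 3, an at least 1.0-fold higher number from compound 1 to compound 3 (0.01 log units; that floor lies within the scatter), lies within the scatter.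

Compound 4 `COc1ccccc1-n1cc(COC(=O)/C(C)=C/CC/C(C)=C/CC/C(C)=C/CC[C@@H]2[C@@]3(C)CCC(=O)C(C)(C)[C@H]3CC[C@@]2(C)O)nn1` differs from compound 3 in one place: 2-methoxyphenyl in place of 4-fluorophenyl on an aromatic nitrogen. Among the compounds with values here, the only comparable change, from 3-hydroxyphenyl to 4-fluorophenyl, moved the number no further than the scatter, so the aryl substituent on the aromatic nitrogen has so far made no difference in this assay that can be seen. Compound 4 is therefore expected to remain at or beyond the limit, with the step from compound 3 estimated as a number no higher from compound 3 to compound 4 (the limit leaves the size open). For compound 4 the estimate in this assay is 150000 nM, within 90000 nM to 300000 nM.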

Compound 4, half-maximal inhibitory concentration: > 150000 nM
Compound 4: no number, only a limit; the forecaster's own chance of this, stated with the estimate: 70%; the middle value sits exactly at the limit.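

In this assay the result for compound 4 is a limit and not a number, and a methoxy-bearing aryl group now sits at the same ceiling as the 4-fluorophenyl of compound 3 and the protected nucleoside of compound 2: the limit of > 150000 nM in this assay, at which 3 of the 4 values shown sit. The step between compound 3 and compound 4 cannot be read, so the exchange of 4-fluorophenyl for 2-methoxyphenyl, which brings in one hydrogen-bond acceptor where there was none, has no size that can be stated. Going by these compounds alone, compound 1 is the only compound here with a number, and the comparison with it gives an at least 1.0-fold higher number from compound 1 to compound 4 (0.01 log units; that floor lies within the scatter), so the 2-methoxyphenyl, like the 4-fluorophenyl, shows no visible separation from the 3-hydroxyphenyl.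

Going by these compounds, it remains open whether an aminophenyl group, a carboxylic acid on the aryl ring or a longer chain in place of the aryl group on the aromatic nitrogen would bring the number in this assay clearly down from the ceiling. On these data alone, how far compound 2, compound 3 and compound 4 lie beyond that ceiling, and whether they differ from one another, also stays open.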